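The source may hold more compounds than are shown below. What is called first, only, known or untested is meant among the compounds shown, and "the series" means these compounds.

Measured so far:
- compound 1, `CCNC(=O)OC[C@H]1OC(n2cnc3c(NC4CCOC4)ncnc32)[C@H](O)[C@@H]1O`, gives 167 nM in an assay on DDT1 cells (Cricetulus griseus) for binding affinity to adenosine receptor A1 (Homo sapiens), read by radioligand binding; a higher number here means a weaker inhibitor, a lower number a stronger inhibitor
- compound 2, `CCCNC(=O)OC[C@H]1OC(n2cnc3c(NC4CCOC4)ncnc32)[C@H](O)[C@@H]1O`, gives 235 nM in this assay

The two compounds share one core and differ only in the length of the chain on the amide-type nitrogen. The step of a 1.4-fold higher number from compound 1 to compound 2 (0.15 log units; within the scatter) lies within the scatter, so on the numbers shown compound 2 stands alongside compound 1 rather than apart from it; the two cannot be told apart by this measurement.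

Compound 3, `CCCCNC(=O)OC[C@H]1OC(n2cnc3c(NC4CCOC4)ncnc32)[C@H](O)[C@@H]1O`, continues the same series. It differs from compound 2 by methyl in place of hydrogen on a saturated chain carbon, three bonds along the chain from an amide-type nitrogen, that is, the chain grows by one further carbon. For the measured compounds named here, the one measured step that bears on this is the step from compound 1 to compound 2, which was the same kind of lengthening one bond closer to the amide-type nitrogen and stayed within the scatter. With nothing else to go on, the expected step of a 1.1-fold higher number from compound 2 to compound 3 (0.04 log units; within the scatter) is small and not beyond the scatter. Compound 3 is therefore estimated at 260 nM in this assay, with a range from 120 nM to 560 nM.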

Compound 3, inhibition constant: 1410 nM
Compound 3: the middle estimate sits 5.4-fold (0.73 log units) below what was measured, outside the stated range (above it).
By their numbers in this assay, from the lowest: compounds 1 and 2 (each within the scatter of the next); then compound 3.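

In this assay, lengthening the chain on the amide-type nitrogen does not have the same effect at each carbon: the ethyl to propyl change stayed within the scatter, whereas propyl to butyl, with the methyl entering three bonds along the chain from an amide-type nitrogen, gives a 6.0-fold higher number from compound 2 to compound 3 (0.78 log units; beyond the scatter) and weakens binding clearly. Measured across both changes, the ethyl chain of the first compound and the butyl chain of the last differ by an 8.4-fold higher number from compound 1 to compound 3 (0.93 log units; beyond the scatter), and in these three compounds the clear weakening appears only once the chain reaches butyl, so the effect of adding a methyl depends on where along the chain it enters. Nothing measured here accounts for why the butyl chain behaves so differently from the two shorter chains.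

The compounds shown leave open whether a longer chain, such as pentyl or hexyl, would raise the number further or whether it would level off. They also leave open whether the same carbon count arranged differently, as a branched isobutyl group or a cyclopropylmethyl group, or a butyl chain ending in a hydroxyl group or an amine, would behave like the butyl chain of compound 3.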